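Removing a Chlorine from Sulfonylureas Tested on Aorta

A few compounds are considered here, and "the series" means these few. Any claim that something is new, unique, unknown or untested is made for them only; others in the source may bear on it.

Of the compounds shown here, three have been tested in a functional assay on thoracic aorta (Rattus norvegicus, strain Wistar), with a stated time of 15 min; on this read-out higher numbers stand for an effect only at larger amounts of compound and lower numbers for an effect already at smaller amounts. Compound 1, `CCOc1ccc(F)cc1C(C)NC(=O)NS(=O)(=O)c1ccc(Cl)cc1`, gives in this assay only the limit > 300000 nM. Compound 2, `COc1ccc(Cl)cc1C(C)NC(=O)NS(=O)(=O)c1ccccc1`, likewise gives in this assay only the limit > 300000 nM. Compound 3, `COc1ccc(Cl)cc1C(C)NC(=O)NS(=O)(=O)c1ccc(Cl)cc1`, also reaches in this assay no more than the limit > 300000 nM. Compounds 3 and 2 differ in one place, (hydrogen in place of chloro on an aromatic carbon); the step between them, a step that the two limits leave unreadable from compound 3 to compound 2, cannot be read in size because of the limit of > 300000 nM in this assay, at which 3 of the 3 values shown sit.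

Among the compounds with values here, the unmeasured compound 4, `CCOc1ccc(F)cc1C(C)NC(=O)NS(=O)(=O)c1ccccc1`, is related to compound 1 by hydrogen in place of chloro on an aromatic carbon, the same change as the one from compound 3 to compound 2. The difference between the cores of compound 1 and compound 3 is not broken down here.

Compound 1 stands only at a limit, > 300000 nM. The measured step that the two limits leave unreadable from compound 3 to compound 2 gives no readable size, so nothing suggests that removing the chloro group brings a compound into the measurable range. The expected step is therefore a step that the limit leaves unreadable from compound 1 to compound 4. For compound 4 the estimate in this assay is 500000 nM, expected to lie between 150000 nM and 3000000 nM, most probably again only a limit.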

Compound 4, half-maximal effective concentration: > 300000 nM
Compound 4 ended at the assay's limit (the forecaster's own chance of this, stated with the estimate: 85%); the middle value is on the limit's open side.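

Within the data shown here, compound 4, like compound 1, gives only a limit in this assay, so swapping 4-chlorophenyl to phenyl yields no new readable step between these two compounds: the limit of > 300000 nM in this assay, at which 4 of the 4 values shown sit.

The compounds shown leave open how large this step really is and whether any change to these structures reaches a measurable value in this assay.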